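This account rests on a few compounds, and the source may have more. Where it says the series, first, only, none or still open, it means among the compounds named here.

Compound 1 `C/C(=N\Nc1nc2ccccc2o1)c1ncccn1`: 30 nM
Compound 2 `CC(C)/C(=N\Nc1nc2ccccc2o1)c1ccccn1`: 14 nM

Both values come from a functional assay on cells (Burkitts lymphoma cell, Homo sapiens) for antiproliferative activity, read by MTT assay; on this read-out lower numbers stand for stronger inhibition and higher numbers for weaker inhibition. Compound 1, at 30 nM, holds the higher of the two numbers, so it is the weaker inhibitor of this pair, and the gap down to compound 2 lies beyond the usual scatter.

Compound 3 `C/C(=N\Nc1nc2ccccc2o1)c1cccnn1` has not yet been measured in this assay. It keeps the core of compound 1 and has pyridazin-3-yl in place of pyrimidin-2-yl on a carbon with a double bond to nitrogen. The two compounds have the same atoms, joined differently.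

Among the compounds with values here, no measured pair isolates this change. Compound 2, at 14 nM, differs from compound 1 in more than one place, so it offers only a rough sense of the range. The expectation therefore stays close to compound 1, with a slight lean towards weaker inhibition. The expected change is a 1.2-fold higher number from compound 1 to compound 3 (0.07 log units; within the scatter), a small step upward that stays within the scatter. For compound 3 the estimated value is 35 nM, with an expected range of 10 nM to 120 nM.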

Compound 3, half-maximal inhibitory concentration: 1300 nM
Estimate against measurement, compound 3: 37-fold (1.57 log units) below; measured number above the stated range.
By their numbers in this assay, from the lowest: compound 2; then compound 1; then compound 3.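

In this assay, within the data shown here, replacing pyrimidin-2-yl with pyridazin-3-yl on a carbon with a double bond to nitrogen gives a 43-fold higher number from compound 1 to compound 3 (1.64 log units; beyond the scatter), a large step that the earlier compounds gave no sign of, since no measured pair had isolated this place. The two groups match in every count available, from heavy atoms and hetero atoms to hydrogen-bond donors, hydrogen-bond acceptors and net charge, and differ only in how the same atoms are joined, so this place in the series tells apart two isomeric rings that those counts cannot separate. No measurement shown here bears on why the step is so large, and the result stands as an observation without an explanation.

With only this one pair isolating the change, the compounds shown cannot tell whether the same swap would cost as much on another core, or with compound 2 as the starting point, which differs from compound 1 in more than one place. They also leave open how this place would respond to an amine or a carboxylic acid on the ring, or how a longer chain on the same carbon would read out.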